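Working notes: from compound 2 to compound 3

A few compounds are considered here, and "the series" means these few. Any claim that something is new, unique, unknown or untested is made for them only; others in the source may bear on it.

In a physicochemical assay for solubility, read by LC-MS, in phosphate buffer, with a stated time of 24 h, at pH 7.4 (a higher number here means a more soluble compound, a lower number a less soluble compound), compound 1 (`C[C@@H]1CC(=O)N(c2cnc(NCc3c(F)ccc4c3CCO4)n3cnnc23)C1`) gives 130000 nM and compound 2 (`C[C@H]1CC(=O)N(c2cnc(NCc3c(F)ccc4c3CCO4)n3cnnc23)C1`) gives 200000 nM. Among the measured compounds shown here, compound 2 therefore stands within the scatter of compound 1, the only other measured compound. The next structure is compound 3 (`CN(c1cccnc1)c1cnc(NCc2c(F)ccc3c2CCO3)n2cnnc12`), which carries the change methyl(pyridin-3-yl)amino in place of 4-methyl-2-oxopyrrolidin-1-yl on an aromatic carbon. For the measured compounds named here, only one measured step bears on this, a 1.5-fold higher number from compound 1 to compound 2 (0.19 log units; within the scatter), and it comes with the fact that compounds 1 and 2 differ only in the configuration as drawn. The 4-methyl-2-oxopyrrolidin-1-yl group stays in place across that step, so it sets no size for replacing the group. The expected step, held loosely, is a 3.3-fold lower number from compound 2 to compound 3 (0.52 log units; beyond the scatter) in this assay. For compound 3 the estimate is 60000 nM, with an expected range of 15000 nM to 200000 nM.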

Compound 3, solubility: 47000 nM
Estimate against measurement, compound 3: 1.3-fold (0.11 log units) above; the measured number falls inside the stated range.
By their numbers in this assay, from the lowest: compound 3; then compounds 1 and 2 (each within the scatter of the next).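

Among the compounds shown here, this aromatic carbon is the first place where a change moves the number in this assay beyond the scatter: methyl(pyridin-3-yl)amino in place of 4-methyl-2-oxopyrrolidin-1-yl gives a 4.3-fold lower number from compound 2 to compound 3 (0.63 log units; beyond the scatter) in this comparison. The same replacement gives a 2.8-fold lower number from compound 1 to compound 3 (0.44 log units; beyond the scatter) from the other starting compound, so the direction holds from both, and both steps are modest. Compounds 1 and 2 stand within the scatter of each other, and their relation is this: the fact that compounds 1 and 2 differ only in the configuration as drawn.

The compounds shown do not separate the contribution of the pyridin-3-yl ring from that of the methyl on the amino nitrogen. On these data alone, how a simple amine or a carboxylic acid on the same aromatic carbon would compare in this assay also stays open.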